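A ring methyl added to compound 2

A few compounds are considered here, and "the series" means these few. Any claim that something is new, unique, unknown or untested is made for them only; others in the source may bear on it.

In a functional assay on HT-29 cells (Homo sapiens) for antiproliferative activity, read by sulforhodamine B assay, with a stated time of 48 h (a higher number here means a weaker inhibitor, a lower number a stronger inhibitor), compound 1 `Cc1ccccc1OS(=O)(=O)c1ccc(N2CCN(C)C2=O)cc1` gives 4800 nM. Compound 2 `CCCN1CCN(c2ccc(S(=O)(=O)Oc3ccccc3C)cc2)C1=O` reads > 100000 nM, and this value is a limit of the assay, not a number. Going by the values given here, the only measured step, an at least 20-fold higher number from compound 1 to compound 2 (1.31 log units; beyond the scatter), is large and beyond the scatter, but it concerns ethyl in place of hydrogen on a saturated chain carbon bound to an amide-type nitrogen in a ring. Compound 3 `CCCN1CCN(c2ccc(S(=O)(=O)Oc3ccc(C)cc3C)cc2)C1=O` differs elsewhere: it has methyl in place of hydrogen on an aromatic carbon, turning 2-methylphenyl into 2,4-dimethylphenyl (methyl in place of hydrogen on an aromatic carbon). Among the compounds with values here, no measured step covers this kind of change, so only a modest move towards a lower number in this assay is expected, and compound 3 may well remain at the limit of > 100000 nM in this assay, at which 1 of the 2 values shown sits. For compound 3 the estimated value is 50000 nM, with an expected range of 8000 nM to 100000 nM. This estimate means an expected at least 2.0-fold lower number from compound 2 to compound 3 (0.30 log units; that floor lies within the scatter).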

Compound 3, half-maximal inhibitory concentration: 26000 nM
Compound 3: the middle estimate sits 1.9-fold (0.28 log units) above what was measured, and the stated range covers the measured number.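

In this assay, the change from 2-methylphenyl to 2,4-dimethylphenyl gives an at least 3.8-fold lower number from compound 2 to compound 3 (0.58 log units; beyond the scatter), so this aromatic carbon, para to a large group, is a place where a single methyl registers beyond the scatter. The earlier step concerned only the chain on the amide-type nitrogen in the ring, so it said nothing about this side of the molecule. Compound 2 reads > 100000 nM, which is a limit of the assay and not a number, so the full size of the step stays open: the limit of > 100000 nM in this assay, at which 1 of the 3 values shown sits.

On these data alone, it remains open whether the same methyl would act alike on compound 1, which carries the shorter chain. Also open, as far as these compounds go, is how an ethyl, a methoxy, a chlorine atom or an amine on this aromatic carbon would read.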